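This account rests on a few compounds, and the source may have more. Where it says the series, first, only, none or still open, it means among the compounds named here.

Compound 1 `COc1ccc(CNc2ncnc3c2ncn3[C@@H]2O[C@H](CO)[C@@H](O)[C@H]2O)c(OC)c1` sits at the limit of a functional assay on K562 cells (Homo sapiens) for antiproliferative activity, with a stated time of 72 h (a higher number here means a weaker inhibitor, a lower number a stronger inhibitor), where compound 1 gives > 166000 nM, a limit of the assay rather than a number. Compound 2 `COc1cc(CNc2ncnc3c2ncn3[C@@H]2O[C@H](CO)[C@@H](O)[C@H]2O)cc(OC)c1O` likewise shows only a limit, giving > 166000 nM in this assay. Compound 3 `OC[C@H]1O[C@@H](n2cnc3c(NCc4ccccc4C(F)(F)F)ncnc32)C(O)C1O` gives > 166000 nM in this assay, again a limit. All three results therefore say the same thing: the limit of > 166000 nM in this assay, at which 3 of the 3 values shown sit. No pair among these compounds differs in a single place, so no measured step is available to set a scale for what a change on the shared core of compound 1 does.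

Compound 4 `OC[C@H]1O[C@@H](n2cnc3c(NCc4ccc(C(F)(F)F)cc4)ncnc32)[C@H](O)[C@@H]1O` is the next compound to be tested. It differs from compound 1 by 4-(trifluoromethyl)phenyl in place of 2,4-dimethoxyphenyl on a saturated chain carbon bound to a nitrogen on an aromatic ring. The neighbouring results give no reason to expect this exchange to lift the compound off the limit: compound 3, whose result > 166000 nM is itself a limit, shows that a trifluoromethyl-bearing ring on the same chain carbon has not yet produced a number. The step in this assay from compound 1 to compound 4 is expected to be none beyond the scatter, most likely a limit again. The expected step is a step that the limit leaves unreadable from compound 1 to compound 4. Compound 4 is estimated at 200000 nM, with a range from 60000 nM to 600000 nM.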

Compound 4, half-maximal inhibitory concentration: > 166000 nM
Compound 4: no number, only a limit; the forecaster's own chance of this, stated with the estimate: 85%; the middle value does not contradict the limit.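

In this assay compound 4 gives > 166000 nM, a limit and not a number. Compound 1 also shows only a limit, so no step can be read from compound 1 to compound 4, and the picture stays as it was: the limit of > 166000 nM in this assay, at which 4 of the 4 values shown sit. The compounds shown leave open which change on the shared core, if any, would give a measured number in this assay.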